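Methoxy to hydroxy: one small change on compound 3

The source may hold more compounds than are shown below. What is called first, only, known or untested is meant among the compounds shown, and "the series" means these compounds.

Three compounds sharing one core have numbers in a functional assay on SW-620 cells (Homo sapiens) for cytotoxicity, read by sulforhodamine B assay, with a stated time of 48 h (a lower number here means a stronger inhibitor, a higher number a weaker inhibitor), and they differ only in the aromatic group: compound 1 `C[C@H]1CC[C@@H]2[C@@H](OC(=O)[C@]23CC(c2ccc(Cl)cc2)=NO3)[C@]2(C)C(=O)C=C[C@@]12O` carries 4-chlorophenyl, compound 2 `C[C@H]1CC[C@@H]2[C@@H](OC(=O)[C@]23CC(c2ccc([N+](=O)[O-])cc2)=NO3)[C@]2(C)C(=O)C=C[C@@]12O` carries 4-nitrophenyl and compound 3 `COc1ccc(C2=NO[C@]3(C2)C(=O)O[C@@H]2[C@H]3CC[C@H](C)[C@]3(O)C=CC(=O)[C@@]23C)cc1OC` carries 3,4-dimethoxyphenyl. Compound 3 gives 86000 nM and compound 1 gives 51000 nM, and these two cannot be told apart, as the step is a 1.7-fold higher number from compound 1 to compound 3 (0.23 log units; within the scatter). Compound 2 gives 9000 nM and is the strongest of the three, with a 5.7-fold lower number from compound 1 to compound 2 (0.75 log units; beyond the scatter) and a 9.6-fold higher number from compound 2 to compound 3 (0.98 log units; beyond the scatter).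

Compound 4 `COc1cc(C2=NO[C@]3(C2)C(=O)O[C@@H]2[C@H]3CC[C@H](C)[C@]3(O)C=CC(=O)[C@@]23C)ccc1O` differs from compound 3 in one place: hydrogen in place of methyl on an oxygen on an aromatic ring. Put simply, this is hydrogen in place of methyl on an oxygen on an aromatic ring, which turns 3,4-dimethoxyphenyl into 4-hydroxy-3-methoxyphenyl. Among the compounds with values here, no measured step makes this exact swap, so the evidence is indirect. Exchanging the entire aromatic group of compound 3 for that of compound 2 gave only a 9.6-fold higher number from compound 2 to compound 3 (0.98 log units; beyond the scatter), and the exchange for that of compound 1 gave a 1.7-fold higher number from compound 1 to compound 3 (0.23 log units; within the scatter). A far smaller edit should therefore move the number little, and no step beyond the scatter is expected. The expected step is a 1.4-fold lower number from compound 3 to compound 4 (0.16 log units; within the scatter). Compound 4 is estimated at 60000 nM, with an expected range from 20000 nM to 130000 nM.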

Compound 4, half-maximal inhibitory concentration: 88000 nM
Beside the measured number, compound 4's estimate is 1.5-fold (0.17 log units) below it; the range from low to high includes it.
By their numbers in this assay, from the lowest: compound 2; then compounds 1, 3 and 4 (each within the scatter of the next).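

Taking the methyl off one oxygen of the 3,4-dimethoxyphenyl group, to give 4-hydroxy-3-methoxyphenyl, leaves the number in this assay unmoved (a 1.0-fold higher number from compound 3 to compound 4 (0.01 log units; within the scatter)), so methoxy and hydroxy cannot be told apart at this place on the aromatic ring, a comparison that the earlier swaps of the whole aromatic group could not offer. Compound 4 also cannot be told apart from the chloro compound (a 1.7-fold higher number from compound 1 to compound 4 (0.24 log units; within the scatter)), while the nitro compound remains clearly separate (a 9.8-fold higher number from compound 2 to compound 4 (0.99 log units; beyond the scatter)), so compound 2 stands alone as the strongest of the four, and compounds 1, 3 and 4 form one group. No other measurement bears on this result, so it stays a plain observation.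

From the compounds shown here alone, whether a longer chain on that oxygen, such as ethoxy or benzyloxy in place of methoxy or hydroxy, would keep the number in the same range remains open. Going by these compounds, it is also open whether an amine or a carboxylic acid on the aromatic ring would give a number close to that of compound 2 or one close to those of the other three compounds.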